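Swapping a Thiazole Amide for a Pyridine Amide

The compounds below may be only part of what the source reports. "The series", "measured", "known", "first", "only" and "open" are said of these compounds alone.

Of the compounds shown here, two built on one shared core have been measured. Compound 1 `O=C(O)CCc1ccc(NC(=O)C(C2CCCCC2)n2c(-c3ccc(Cl)cc3)nc3cc(F)c(F)cc32)cc1` carries a 4-(2-carboxyethyl)phenyl group on an amide-type nitrogen; in a functional assay for agonist activity at Bile acid receptor (Homo sapiens), read by a luciferase reporter (a lower number here means a smaller maximal response, a higher number a larger maximal response), compound 1 gives 18%. Compound 2 `Cc1nc(NC(=O)C(C2CCCCC2)n2c(-c3ccc(Cl)cc3)nc3cc(F)c(F)cc32)sc1C(=O)O` carries a 5-carboxy-4-methyl-1,3-thiazol-2-yl group at the same place, and in this assay compound 2 gives 10%. The step of a number 8 percentage points lower from compound 1 to compound 2 (within the scatter) means that the two values cannot be told apart, so compound 2 stands together with compound 1 rather than apart from it.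

Compound 3 `O=C(O)c1ccc(NC(=O)C(C2CCCCC2)n2c(-c3ccc(Cl)cc3)nc3cc(F)c(F)cc32)nc1` is the next variation. The change from compound 2 is 5-carboxypyridin-2-yl in place of 5-carboxy-4-methyl-1,3-thiazol-2-yl on an amide-type nitrogen. Among the measured compounds shown here, the only measured step that bears on it is the one from compound 1 to compound 2, which also replaced the whole group on the amide-type nitrogen and stayed within the scatter. Replacing the thiazole with a pyridine while keeping the carboxylic acid is therefore expected to give no step beyond the scatter in this assay, so the estimated step is a number 2 percentage points higher from compound 2 to compound 3 (within the scatter). Compound 3 is expected to reach 12% in this assay, within a range from 3% to 25%.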

Compound 3, largest response reached (reported as efficacy), in percent of the reference or control that the assay uses: 20%
The estimate for compound 3 lay 8 percentage points below the measured number; measured number inside the range.
By their numbers in this assay, from the lowest: compounds 2, 1 and 3 (each within the scatter of the next).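

In this assay the swap of a five-membered aromatic ring with 2 hetero atoms for a six-membered aromatic ring with 1 hetero atom gives a number 10 percentage points higher from compound 2 to compound 3 (within the scatter) and the comparison with the phenyl compound gives a number 2 percentage points higher from compound 1 to compound 3 (within the scatter). On the amide-type nitrogen, then, 4-(2-carboxyethyl)phenyl, 5-carboxy-4-methyl-1,3-thiazol-2-yl and 5-carboxypyridin-2-yl cannot be told apart in this read-out, even though the last of these has no sulfur and no methyl group and places its carboxylic acid directly on the ring. The data at hand offer no explanation for why these three groups read alike.

All three groups carry a carboxylic acid, so the compounds shown leave open whether the acid matters at all, a question that a methyl ester, a primary amide or a tetrazole on the same pyridine would address. They also leave open whether any group at this place can move the maximal response beyond the scatter, for example a pyridine bearing an amine or a longer chain ending in the acid.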